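The source may hold more compounds than are shown below. What is called first, only, known or untested is meant among the compounds shown, and "the series" means these compounds.

Cytotoxicity notes on the shared core. In a functional assay on HFF cells (Homo sapiens) for cytotoxicity (on this read-out lower numbers stand for stronger inhibition and higher numbers for weaker inhibition), compound 1 `CSc1nc(N)c2ccn(COCCO)c2n1` gives > 100000 nM, which is a limit of the assay and not a number. Compound 2 `Nc1ncnc2c1ccn2COCCO` gives > 100000 nM in this assay, again a limit. Compound 3 `Nc1nc(Cl)nc2c1ccn2COCCO` gives > 100000 nM in this assay, likewise a limit. All three values sit at the limit of > 100000 nM in this assay, at which 3 of the 3 values shown sit, so compound 3 stands nowhere apart from the other two on these numbers. The steps a step that the two limits leave unreadable from compound 1 to compound 2, a step that the two limits leave unreadable from compound 1 to compound 3 and a step that the two limits leave unreadable from compound 2 to compound 3 are each of unreadable size, as both ends of each are limits.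

Compound 4 `Nc1nc(N)c2ccn(COCCO)c2n1` differs from compound 3 by amino in place of chloro on an aromatic carbon of a six-membered aromatic ring with 2 nitrogen, between two ring nitrogen atoms, meta to a fused ring and meta to an amino group. The three measured steps touch the same carbon of the core, but none has a readable size, so they give no direction for this change. The expectation for compound 4 is that its cytotoxicity stays at the limit, with an expected step of a number no higher from compound 3 to compound 4 (the limit leaves the size open) not beyond the scatter. Compound 4 is estimated at 100000 nM in this assay, with a range from 50000 nM to 300000 nM, and most likely reported as a limit once more.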

Compound 4, half-maximal inhibitory concentration: > 100000 nM
Compound 4: a limit, no number; the forecaster's own chance of this, stated with the estimate: 85%; the middle value sits exactly at the limit.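

Compound 4 joins compound 1, compound 2 and compound 3 in this assay, and no step among these four compounds can be read, as each value is a limit and not a number: the limit of > 100000 nM in this assay, at which 4 of the 4 values shown sit. The compounds shown leave open whether, in this assay, any group on this aromatic carbon of the shared core gives a readable number.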